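Swapping a Small Ring for a Branched Chain

The source may hold more compounds than are shown below. What is called first, only, known or untested is meant among the compounds shown, and "the series" means these compounds.

Of the compounds shown here, three that share one core have been tested in a functional assay on EC9706 cells (Homo sapiens) for antiproliferative activity, read by MTT assay, with a stated time of 72 h; on this read-out higher numbers stand for weaker inhibition and lower numbers for stronger inhibition. Compound 1 `O=C1OCC=C1CSC(=S)NC1CC1` gives 53600 nM. Compound 2 `CN(C)C(=S)SCC1=CC(=O)OC1` gives 7550 nM, and compound 3 `O=C1OCC=C1CSC(=S)N1CCOCC1` gives 26000 nM. Compound 1 therefore stands at the highest number of the three, meaning it is the weakest inhibitor of this small group: its distance to compound 3 already lies beyond the usual scatter of repeated measurements, and its distance to compound 2 is wider still.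

The next compound, compound 4 `CC(C)NC(=S)SCC1=CCOC1=O`, has not yet been measured. It differs from compound 1 in a single place: isopropyl in place of cyclopropyl on an amide-type nitrogen. Among the measured compounds shown here, no pair of measured compounds differs in exactly this way, so there is no direct precedent in these data for the size of the step. The group that leaves and the group that enters carry the same count of heavy atoms, and only the ring is lost, so a modest shift is the most reasonable expectation, most likely one that does not reach beyond the scatter, with perhaps a slight lean toward stronger inhibition. Compound 4 is expected to give about 40000 nM, with a plausible range from 15000 nM to 110000 nM. The step from compound 1 to compound 4 is accordingly expected to be a 1.3-fold lower number from compound 1 to compound 4 (0.13 log units; within the scatter).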

Compound 4, half-maximal inhibitory concentration: 59400 nM
Estimate against measurement, compound 4: 1.5-fold (0.17 log units) below, and the stated range covers the measured number.
By their numbers in this assay, from the lowest: compound 2; then compound 3; then compounds 1 and 4 (each within the scatter of the next).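

In this assay, among the compounds shown here, replacing cyclopropyl with isopropyl on the amide-type nitrogen gives a 1.1-fold higher number from compound 1 to compound 4 (0.04 log units; within the scatter) and so provides the first direct comparison of two compounds that differ in one place. At this position, with the same count of heavy atoms in the entering and leaving groups, losing the three-membered ring produces no change that this read-out can separate from ordinary repeat variation. The result therefore shows that the ring itself is not needed to keep the number where it stands, although no measured information here explains why the two groups behave alike.

What the compounds shown leave open is how far this tolerance extends, since cyclopropyl and isopropyl are close in size and a larger group such as cyclohexyl or a longer chain such as n-butyl could behave differently on the same nitrogen. Going by these compounds, it also remains open whether an aromatic ring such as phenyl, or a chain ending in a hydroxyl group, would move the number beyond the scatter in either direction.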